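The source may report more compounds than this note shows. Statements on the series, on what has been measured and on what is new or still open speak of the compounds shown alone.

Measured compounds:
compound 1, `COc1cc2cc(Oc3ccc(NC(=O)Nc4ccccc4)cc3)c(C)nc2cc1OC`, 78.8%
compound 2, `COc1cc2cc(Oc3ccc(NC(=O)Nc4ccc(C)cc4)cc3)c(C)nc2cc1OC`, 91.5%

For the measured compounds named here, in a functional assay on SK-MEL-2 cells (Homo sapiens) for inhibition, read by sulforhodamine B assay, with a stated time of 48 h, tested at 10 uM (a higher number here means a weaker effect of the compound at the concentration tested, a lower number a stronger effect), compound 2 gives 91.5%, the higher of the two numbers; its nearest neighbour is compound 1 with 78.8%, and the only step in the set is a number 12.7 percentage points higher from compound 1 to compound 2 (beyond the scatter).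

Compound 3, `COc1cc2cc(Oc3ccc(NC(=O)Nc4ccc(C(F)(F)F)cc4)cc3)c(C)nc2cc1OC`, is not yet measured. It differs from compound 2 by trifluoromethyl in place of methyl on an aromatic carbon, at the place where compound 2 already carries its methyl. Going by the values given here, the one measured step bears on it only loosely: it replaced hydrogen with methyl at that same place and raised the read-out in this assay by a modest amount. Among the compounds with values here, no step with trifluoromethyl exists in the set, so there is no direct basis for the direction from compound 2 to compound 3.

Compound 3 is therefore expected to stay close to compound 2, with a number 3.5 percentage points lower from compound 2 to compound 3 (within the scatter) estimated as within the scatter, giving an estimate of 88%, range 72% to 100%.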

Compound 3, a percentage reported as activity, at one concentration (the size of the read-out at that concentration, not a potency): 76.7%
Compound 3: middle estimate off by 11.3 percentage points, on the high side, within the range that was stated.
By their numbers in this assay, from the lowest: compounds 3 and 1 (each within the scatter of the next); then compound 2.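

In this assay, the position on the aromatic ring para to a large group is sensitive to which substituent it carries, not only to whether it carries one: trifluoromethyl in place of methyl gives a number 14.8 percentage points lower from compound 2 to compound 3 (beyond the scatter) and so moves toward a stronger effect. Set against the unsubstituted compound, trifluoromethyl gives a number 2.1 percentage points lower from compound 1 to compound 3 (within the scatter) and does not separate from hydrogen, so among these three compounds only methyl stands apart at this place. Nothing shown here accounts for the difference between methyl and trifluoromethyl.

On these data alone, whether an amine, a methoxy group or a carboxylic acid at this place would give a number clearly lower than those of compound 1 and compound 3 remains open. As far as these compounds go, all three read-outs come from a single concentration, so they show only a stronger or weaker effect at that concentration, and how the compounds compare at other concentrations also remains open.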